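This account rests on a few compounds, and the source may have more. Where it says the series, first, only, none or still open, it means among the compounds named here.

Compound 1 `COc1ccccc1N1CCN(CCCCC(=O)c2cccc(O)c2)CC1` and compound 2 `COc1ccccc1N1CCN(CCCCCC(=O)c2ccc(O)cc2)CC1` open the series. In an assay on isolated protein for binding affinity to 5-hydroxytryptamine receptor 7 (Rattus norvegicus) (on this read-out higher numbers stand for weaker inhibition and lower numbers for stronger inhibition), compound 1 gives 15 nM, and compound 2 gives 23.7 nM in the same assay; the two values lie within the usual scatter of each other. Compound 3 `CN1CCN(CCCCCC(=O)c2ccccc2O)CC1` is the odd one out: in this assay compound 3 gives only a limit, > 1000 nM, so no number is known for it, as shown by the limit of > 1000 nM in this assay, at which 1 of the 3 values shown sits. Among the three values shown, compound 3 therefore stands apart, with compound 1 and compound 2 both carrying numbers while compound 3 carries a limit.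

Compound 4 `O=C(CCCCCN1CCN(c2nc3ccccc3[nH]2)CC1)c1ccccc1O` has not yet been measured. It differs from compound 3 in one place, (1H-benzimidazol-2-yl in place of methyl on an amine nitrogen in a ring), that is, 1H-benzimidazol-2-yl in place of methyl on an amine nitrogen in a ring. Among the compounds with values here, no step between measured compounds covers this change. Still, the move from compound 3 to compound 4 is expected to go toward stronger inhibition, well beyond the scatter, as an at least 10-fold lower number from compound 3 to compound 4 (1.00 log units; beyond the scatter). For compound 4 in this assay the estimate is 100 nM, with a range from 20 nM to 500 nM.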

Compound 4, inhibition constant: 682 nM
The estimate for compound 4 lay 6.8-fold (0.83 log units) below the measured number; the whole stated range lies below it.
By their numbers in this assay, from the lowest: compounds 1 and 2 (each within the scatter of the next); then compound 4. At a limit, above all of these: compound 3.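

On the amine nitrogen in the ring, 1H-benzimidazol-2-yl in place of methyl gives compound 4 a measured number in this assay, which compound 3 lacks. The change gives an at least 1.4-fold lower number from compound 3 to compound 4 (0.16 log units; that floor lies within the scatter), so the data fix only a floor for this step, and that floor does not by itself establish a change beyond the usual scatter. The true size of the step stays unknown because compound 3 carries only a limit: the limit of > 1000 nM in this assay, at which 1 of the 4 values shown sits.

The compounds shown leave open how far the step really runs and whether a different group on this ring nitrogen, such as a benzyl group or an ethyl group, would give a lower number. Compound 1 and compound 2 differ from compound 4 in more than one place, so they cannot settle what this single change contributes.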